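From Piperidin-1-yl to Isopropyl in the Mouse

A few compounds are considered here, and "the series" means these few. Any claim that something is new, unique, unknown or untested is made for them only; others in the source may bear on it.

In a functional assay on the whole organism with Mus musculus as the target (a lower number here means that less compound is needed, a higher number that more compound is needed for the effect), compound 1 `Cc1c(C)c2c(c(C)c1N)CC(C)(C)O2` gives 7.8 mg/kg. Compound 2 `Cc1c(N)c(C)c2c(c1CN(C)C)OC(C)(C)C2` gives only a limit, > 50 mg/kg. Compound 3 `Cc1c(N)c(C)c2c(c1CN1CCCCC1)OC(C)(C)C2` also gives only a limit, > 50 mg/kg. It therefore stands at the limit of > 50 mg/kg in this assay, at which 2 of the 3 values shown sit.

Dimethylamino in place of hydrogen on a saturated chain carbon bound to an aromatic carbon produced an at least 6.4-fold higher number from compound 1 to compound 2 (0.80 log units; beyond the scatter). Piperidin-1-yl at that place produced an at least 6.4-fold higher number from compound 1 to compound 3 (0.80 log units; beyond the scatter). On these data alone, the comparison of the two groups remains open, with a step that the two limits leave unreadable from compound 2 to compound 3.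

Compound 4 `Cc1c(N)c(C)c2c(c1CC(C)C)OC(C)(C)C2` carries isopropyl in place of piperidin-1-yl on that same carbon: isopropyl in place of piperidin-1-yl on a saturated chain carbon bound to an aromatic carbon. Among the measured compounds shown here, no measured step covers a group without nitrogen, so the two steps from compound 1 are the closest guide. They suggest that leaving piperidin-1-yl could recover part of the loss, though not necessarily all of it, with compound 1 at 7.8 mg/kg as the reference. The estimated change is an at least 3.3-fold lower number from compound 3 to compound 4 (0.52 log units; beyond the scatter). Compound 4 is expected at 15 mg/kg. The estimated range for compound 4 runs from 4 mg/kg to 60 mg/kg.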

Compound 4, dose for 50% inhibition: 13.3 mg/kg
The estimate for compound 4 lay 1.1-fold (0.05 log units) above the measured number; the range from low to high includes it.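

In this assay, a group on the saturated chain carbon bound to an aromatic carbon does not by itself bring a loss beyond the scatter: isopropyl in place of hydrogen gives a 1.7-fold higher number from compound 1 to compound 4 (0.23 log units; within the scatter). The two groups with nitrogen now separate from isopropyl, with an at least 3.7-fold lower number from compound 3 to compound 4 (0.57 log units; beyond the scatter) for piperidin-1-yl and an at least 3.7-fold lower number from compound 2 to compound 4 (0.57 log units; beyond the scatter) for dimethylamino. Compound 2 and compound 3 both remain limits, so these two steps give minimum sizes only: the limit of > 50 mg/kg in this assay, at which 2 of the 4 values shown sit.

On these data alone, whether the nitrogen itself separates these compounds stays open, as does how dimethylamino and piperidin-1-yl compare with each other. How a cyclohexyl group or a carboxylic acid on that carbon would read in this assay also remains an open question.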